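A few compounds are considered here, and "the series" means these few. Any claim that something is new, unique, unknown or untested is made for them only; others in the source may bear on it.

Compound 1 `CN(C)C(=O)c1cc2cnc(Nc3ccc(NC(=O)C4(C(=O)Nc5cccc(F)c5)CC4)cc3)nc2n1C1CCCC1` is the reference point. Within the data shown here, in a functional assay on A549 cells (Homo sapiens) for inhibition, read by CCK-8 assay, with a stated time of 72 h, tested at 1 uM (a lower number here means less inhibition of growth, a higher number more inhibition of growth at the concentration tested), compound 1 gives 33.2%, the middle of the three numbers measured so far. Compound 2 `CN(C)C(=O)c1cc2cnc(Nc3ccc(NC(=O)C4(C(=O)Nc5ccccc5F)CC4)cc3)nc2n1C1CCCC1` reaches 79.1%, while the much smaller compound 3 `Nc1ccc(NC(=O)C2(C(=O)Nc3ccc(F)cc3)CC2)cc1F` gives 16.3%. Compound 3 lacks the core of compound 1, so it says little about a change to a single group.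

Compound 4 `Cc1ccc(NC(=O)C2(C(=O)Nc3ccc(Nc4ncc5cc(C(=O)N(C)C)n(C6CCCC6)c5n4)cc3)CC2)cc1` keeps the core of compound 1 and alters one group, with 4-methylphenyl in place of 3-fluorophenyl on an amide-type nitrogen.

Among the measured compounds shown here, only one measured step touches this place. The swap to 2-fluorophenyl gives a number 45.9 percentage points higher from compound 1 to compound 2 (beyond the scatter), well beyond the scatter, which shows that a change here can matter greatly in this assay. For the measured compounds named here, that step involves a different group, however, and no measured compound carries a 4-methylphenyl, so neither its size nor its direction carries over directly. A small rise that stays within the scatter is the modest expectation, with a wide margin on both sides. The expected change is a number 6.8 percentage points higher from compound 1 to compound 4 (within the scatter). For compound 4 the estimated value is 40%, with an expected range of 15% to 70%.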

Compound 4, percent growth inhibition at one concentration: 40.2%
Compound 4: middle estimate off by 0.2 percentage points, on the low side; the measured number falls inside the stated range.
By their numbers in this assay, from the lowest: compound 3; then compounds 1 and 4 (each within the scatter of the next); then compound 2.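

In this assay, 4-methylphenyl in place of 3-fluorophenyl gives a number 7 percentage points higher from compound 1 to compound 4 (within the scatter) and so leaves these two groups on the amide-type nitrogen indistinguishable, even though they differ in carrying a fluorine or a methyl and in where that group sits on the phenyl ring. By contrast, 4-methylphenyl in place of 2-fluorophenyl gives a number 38.9 percentage points lower from compound 2 to compound 4 (beyond the scatter) and so shows that, among the three compounds sharing the core, only compound 2 stands apart, which means the large rise seen earlier does not come with every change of group at this place. Nothing available explains why compound 2 stands apart.

The compounds shown leave open whether the high number belongs to fluorine specifically or to any small group placed as in 2-fluorophenyl, a question that 2-methylphenyl or 2-chlorophenyl on the same core would address. They also leave open how a plain phenyl, with no added group at all, or a phenyl carrying a carboxylic acid or an amine would compare on this amide-type nitrogen.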